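Swapping a Hydroxyphenyl for a Methoxyphenyl: One Expectation

This account rests on a few compounds, and the source may have more. Where it says the series, first, only, none or still open, it means among the compounds named here.

Compound 1 `O=C1O/C(=C\Cn2cc(-c3cc(F)cc(F)c3)nn2)C(OCc2ccccc2)=C1OCc1ccccc1`: "not active" (no number reported)
Compound 2 `O=C1O[C@H]([C@@H](O)Cn2cc(-c3cccc(O)c3)nn2)C(OCc2ccccc2)=C1OCc1ccccc1`: 54100 nM
Compound 3 `CC(C)(C)OC(=O)N1CCN(C(=S)SCc2cn(C[C@H](O)[C@H]3OC(=O)C(OCc4ccccc4)=C3OCc3ccccc3)nn2)CC1`: > 100000 nM

Within the data shown here, in a functional assay on CFPAC-1 cells (Homo sapiens) for antiproliferative activity, read by MTT assay, with a stated time of 72 h (a lower number here means a stronger inhibitor, a higher number a weaker inhibitor), compound 2 gives 54100 nM, the only full number among the three measured compounds. Compound 1 is recorded as "not active" (no number reported). For compound 3 the entry > 100000 nM is a limit of the assay, not a number; it sits at the limit of > 100000 nM in this assay, at which 1 of the 3 values shown sits. Compound 4 `COc1ccccc1-c1cn(C[C@H](O)[C@H]2OC(=O)C(OCc3ccccc3)=C2OCc2ccccc2)nn1` differs from compound 2 by 2-methoxyphenyl in place of 3-hydroxyphenyl on an aromatic carbon. Among the measured compounds shown here, no measured pair shows what such a change does, so its direction is open. All three measured compounds are weak, and compound 4 is expected to remain weak as well. The expected step is a 1.3-fold higher number from compound 2 to compound 4 (0.11 log units; within the scatter). Compound 4 is therefore estimated at 70000 nM, within a range from 25000 nM to 200000 nM.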

Compound 4, half-maximal inhibitory concentration: > 100000 nM
Compound 4: no number, only a limit (the forecaster's own chance of this, stated with the estimate: 45%); middle value at least 1.4-fold (0.15 log units) from the limit.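

Among these compounds, this pair gives the first step at this position between compounds that differ in one place: an at least 1.8-fold higher number from compound 2 to compound 4 (0.26 log units; that floor lies within the scatter). From the compounds shown here alone, the entry for compound 4 is a limit, not a number, so the true size of the step remains unknown, and nothing here points to a stronger inhibitor with 2-methoxyphenyl. Compound 4 joins compound 3 at the top of the range: the limit of > 100000 nM in this assay, at which 2 of the 4 values shown sit.

The group's position and its oxygen substituent change together here, and their contributions cannot be separated. Going by these compounds, it also remains open how an aminophenyl group or a carboxylic acid would behave at this position.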